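The source may hold more compounds than are shown below. What is called first, only, known or untested is meant among the compounds shown, and "the series" means these compounds.

Of the compounds shown here, three built on one shared core have been measured in a functional assay on NCI-H460 cells (Homo sapiens) for cytotoxicity, read by MTT assay, with a stated time of 72 h; a higher number here means a weaker inhibitor, a lower number a stronger inhibitor. Compound 1 `CN(C)Cc1ccc2nc(NC(=O)N/N=C/c3cn(Cc4ccccc4)c4ccccc34)sc2c1` gives 400 nM, compound 2 `CN(C)Cc1ccc2nc(NC(=O)N/N=C/c3cn(Cc4ccc(C(C)(C)C)cc4)c4ccccc34)sc2c1` gives 810 nM, and compound 3 `CCN(CC)Cc1ccc2nc(NC(=O)N/N=C/c3cn(Cc4ccc(Cl)c(Cl)c4)c4ccccc34)sc2c1` gives 610 nM. The number for compound 3 sits between those of compound 1 and compound 2, and its gap to each of them lies within the usual scatter. Among the measured compounds shown here, the only pair of measured compounds that differs in a single place shows a 2.0-fold higher number from compound 1 to compound 2 (0.31 log units; beyond the scatter), and that change, a tert-butyl group in place of hydrogen on an aromatic carbon, sits on a different part of the molecule from the change considered here.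

Compound 4 `CN(C)Cc1ccc2nc(NC(=O)N/N=C/c3cn(Cc4ccc(Cl)c(Cl)c4)c4ccccc34)sc2c1` differs from compound 3 in one place: dimethylamino in place of diethylamino on a saturated chain carbon bound to an aromatic carbon. For the measured compounds named here, no measured pair shows this exchange of amine, so nothing among the three compounds speaks for a shift in either direction in this assay. The expected step is a 1.0-fold lower number from compound 3 to compound 4 (0.01 log units; within the scatter), that is, nothing beyond the scatter. The estimate for compound 4 is 600 nM, with a range from 300 nM to 1200 nM.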

Compound 4, half-maximal inhibitory concentration: 1360 nM
The estimate for compound 4 lay 2.3-fold (0.36 log units) below the measured number; measured number above the stated range.
By their numbers in this assay, from the lowest: compounds 1, 3, 2 and 4 (each within the scatter of the next, the first and the last beyond it).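

In this assay the choice of amine turns out to count: dimethylamino in place of diethylamino gives a 2.2-fold higher number from compound 3 to compound 4 (0.35 log units; beyond the scatter) and so moves the number beyond the scatter, in a series where this exchange had not been seen before. With dimethylamino held fixed, 3,4-dichlorophenyl in place of phenyl gives a 3.4-fold higher number from compound 1 to compound 4 (0.53 log units; beyond the scatter) as a second step beyond the scatter, while 3,4-dichlorophenyl in place of 4-(tert-butyl)phenyl gives a 1.7-fold higher number from compound 2 to compound 4 (0.23 log units; within the scatter) and does not separate those two compounds. Nothing measured here offers an explanation for either shift.

Going by these compounds, whether the amine step would keep its size with phenyl or 4-(tert-butyl)phenyl in place of 3,4-dichlorophenyl remains open. So does how a ring amine such as pyrrolidine or morpholine would compare with dimethylamino and diethylamino on that same chain carbon.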